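The source may hold more compounds than are shown below. What is called first, only, known or untested is meant among the compounds shown, and "the series" means these compounds.

Measured compounds:
compound 1 `CC/C(=C(/c1ccc(/C=C/C(=O)O)cc1)c1cc2ccccc2[nH]1)c1ccccc1C`, 33 nM
compound 2 `CC/C(=C(/c1ccc(/C=C/C(=O)O)cc1)c1cc2ccccc2[nH]1)c1ccc(Cl)cc1`, 343 nM

Compound 2 gives the highest of the two numbers in a functional assay on MCF7 cells (Homo sapiens) for inhibition; on this read-out lower numbers stand for stronger inhibition and higher numbers for weaker inhibition; its nearest neighbour is compound 1, which sits a large step lower, as a 10-fold higher number from compound 1 to compound 2 (1.02 log units; beyond the scatter) shows, a step that comes from 4-chlorophenyl in place of 2-methylphenyl on the shared core. Compound 3 `CC/C(=C(/c1ccc(/C=C/C(=O)O)cc1)c1cc2ccccc2[nH]1)c1ccc(Cl)c(C)c1` is not yet measured. It differs from compound 2 by methyl in place of hydrogen on an aromatic carbon. Among the compounds with values here, no measured pair shows this very change; the one measured step, from compound 1 to compound 2, tells only that altering the substituent pattern of this aromatic ring can shift the read-out a great deal. Since the methyl enters at a position not sampled in compound 1 or compound 2, the direction of its effect is uncertain, and the expectation is a step near the scatter, a 1.6-fold lower number from compound 2 to compound 3 (0.19 log units; within the scatter). Compound 3 is therefore estimated at 220 nM, within 70 nM to 700 nM in this assay.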

Compound 3, half-maximal inhibitory concentration: 840 nM
Estimate against measurement, compound 3: 3.8-fold (0.58 log units) below, outside the stated range (above it).
By their numbers in this assay, from the lowest: compound 1; then compound 2; then compound 3.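

In this assay, methyl placed ortho to the chloro group weakens inhibition rather than strengthening it (a 2.4-fold higher number from compound 2 to compound 3 (0.39 log units; beyond the scatter)), a modest step but one beyond the scatter. Adding a methyl to the ring therefore does not bring the number back toward that of the 2-methylphenyl compound: the 4-chloro-3-methylphenyl group stands furthest from it (a 25-fold higher number from compound 1 to compound 3 (1.41 log units; beyond the scatter)), the widest gap among the compounds shown. No evidence is available that bears on the reason for this loss at this position.

On these data alone, it remains open whether the loss belongs to methyl itself or would also follow with an ethyl or a methoxy group on the same carbon. As far as these compounds go, it also remains open how much of the large gap to compound 1 comes from the chloro group and how much from where the methyl sits.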